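Exchanging methyl for acetamido in a cytotoxicity read-out

This account rests on a few compounds, and the source may have more. Where it says the series, first, only, none or still open, it means among the compounds named here.

In an ADME assay on L02 cells (Homo sapiens) for cytotoxicity, read by MTT assay, with a stated time of 24 h (on this read-out lower numbers stand for stronger inhibition and higher numbers for weaker inhibition), two compounds have been read so far. Compound 1 `CN1C/C(=C\c2ccc(C#N)cc2)C(=O)/C(=C/c2cccnc2)C1` returns > 20000 nM as a limit of the assay and not as a number. Within the data shown here, compound 2 `Cc1ccc(S(=O)(=O)N2C/C(=C\c3cccnc3)C(=O)/C(=C/c3ccccc3F)C2)cc1` gives 14900 nM as the only actual number in this small set, with no measured neighbour to place it against.

Compound 3 `CC(=O)Nc1ccc(S(=O)(=O)N2C/C(=C\c3cccnc3)C(=O)/C(=C/c3ccccc3F)C2)cc1` keeps the core of compound 2 and carries acetamido in place of methyl on an aromatic carbon, para to a large group (acetamido in place of methyl on an aromatic carbon). Among the measured compounds shown here, no two measured compounds differ in just one place, so nothing here gauges such a change directly.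

Compound 2 at 14900 nM is therefore the only anchor for the expectation. In this assay a small move is expected, with a 1.1-fold higher number from compound 2 to compound 3 (0.06 log units; within the scatter) estimated to lean toward weaker inhibition while staying within the usual scatter. It would be no surprise if compound 3 also returned only a limit, as compound 1 did. For compound 3 the estimated value is 17000 nM with an expected range from 9000 nM to 32000 nM for repeated measurements.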

Compound 3, half-maximal inhibitory concentration: 15600 nM
Estimate against measurement, compound 3: 1.1-fold (0.04 log units) above; the measured number falls inside the stated range.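

The result gives this assay its first step between compounds that differ in one place: acetamido in place of methyl, on an aromatic carbon para to a large group, gives a 1.0-fold higher number from compound 2 to compound 3 (0.02 log units; within the scatter). At this position, the read-out therefore does not separate 4-methylphenyl from 4-acetamidophenyl, even though the entering group adds a hydrogen-bond donor and a hydrogen-bond acceptor that methyl does not carry. Compound 1 remains the only compound held at a limit and not at a number, and this limit marks how little room the read-out leaves toward weaker inhibition: the limit of > 20000 nM in this assay, at which 1 of the 3 values shown sits.

Going by these compounds, whether an amine or a carboxylic acid on this aromatic carbon would give a number clearly apart from those of compound 2 and compound 3 remains open, as does the effect of a longer chain in place of acetamido. On these data alone, it is also open whether the exchange of methyl for acetamido would read the same way on another core, since this single step rests on the core of compound 2 alone.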